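Cytotoxicity limits and the aryl swap from compound 3

The source may hold more compounds than are shown below. What is called first, only, known or untested is meant among the compounds shown, and "the series" means these compounds.

In an ADME assay on BJ cells (Homo sapiens) for cytotoxicity, with a stated time of 72 h (a higher number here means that more compound is needed for the effect, a lower number that less compound is needed), compound 1 `COc1ccc(-c2nc3c(c(C)nn3-c3ccccc3)c(-c3ccccc3O)c2C#N)cc1` gives > 23000 nM, which is a limit and not a number. Compound 2 `CCc1ccc(-c2nc3c(c(C)nn3-c3ccccc3)c(-c3ccccc3C#N)c2C#N)cc1` gives > 20000 nM, also a limit. Compound 3 `Cc1cccc(-c2nc3c(c(C)nn3-c3ccccc3)c(-c3ccccc3O)c2C#N)c1` gives > 20000 nM, again a limit. Compound 3 therefore has no numerical value and stands at the limit of > 20000 nM in this assay, at which 2 of the 3 values shown sit. Compound 1 alone stands at the limit of > 23000 nM in this assay, at which 1 of the 3 values shown sits.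

Compound 4 `Cc1nn(-c2ccccc2)c2nc(-c3ccc(C(F)(F)F)cc3)c(C#N)c(-c3ccccc3O)c12` keeps the 2-hydroxyphenyl group of compound 3 and carries 4-(trifluoromethyl)phenyl in place of 3-methylphenyl on an aromatic carbon, ortho to a cyano group: 4-(trifluoromethyl)phenyl in place of 3-methylphenyl on an aromatic carbon.

Within the data shown here, one measured step bears on this place: a step that the two limits leave unreadable from compound 1 to compound 3, with 3-methylphenyl in place of 4-methoxyphenyl. Among the measured compounds shown here, it gives no size to carry forward, and no compound with a number in the set shows what a trifluoromethyl group does here. Given a step that the two limits leave unreadable from compound 1 to compound 3, no step beyond the usual scatter is expected in this assay, and no direction can be assigned. A report of a limit again is the likeliest outcome for compound 4.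

The step is expected to be a number no higher from compound 3 to compound 4 (the limit leaves the size open). Compound 4 is estimated at 20000 nM, with an expected range of 9000 nM to 35000 nM.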

Compound 4, half-maximal effective concentration: 22900 nM
The estimate for compound 4 lay 1.1-fold (0.06 log units) below the measured number; low and high end bracket the measured number.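

In this assay compound 4 gives 22900 nM, the only actual number among the compounds shown, so this place on the shared core, ortho to a cyano group, now has a measured reference with the 2-hydroxyphenyl group kept. Compound 3, which carries 3-methylphenyl at the same place, still has only a limit: the limit of > 20000 nM in this assay, at which 2 of the 4 values shown sit. The change from methoxy to trifluoromethyl on the aryl group reads as a number no higher from compound 1 to compound 4 (the limit leaves the size open), which gives a direction but no size, and the step between compound 3 and compound 4 cannot be read.

How far any aryl group at this place moves the value in this assay stays open, since only one of the compounds shown has a number to compare against. Going by these compounds, what an amine or a carboxylic acid on this aryl group would give is also open, as is whether a number could be obtained at all for the compounds that so far report only limits.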